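The source may hold more compounds than are shown below. What is called first, only, known or untested is meant among the compounds shown, and "the series" means these compounds.

Among the measured compounds shown here, in an ADME assay on MT2 cells (Homo sapiens) for cytotoxicity, read by XTT assay, with a stated time of 4 days (on this read-out lower numbers stand for higher toxicity in this test and higher numbers for lower toxicity in this test), compound 2 (`Cc1nc(C(NC(=O)C(=O)Nc2ccc(Cl)c(F)c2)C2CCCCN2)sc1CO`) gives 77800 nM as the only true number so far. Compound 1 (`Cc1ccc(NC(=O)C(=O)NC(c2nc(C)c(CO)s2)C2CCCCN2)c(F)c1`) stands at > 109000 nM as a limit of the assay. Compound 3 (`Cc1nc(C(NC(=O)C(=O)Nc2ccc(Cl)c(F)c2)C2CCCCN2)sc1CCO`) stands at > 41000 nM and this is also a limit. Compound 4 (`CC(=O)c1ccc(NC(=O)C(=O)NC(c2nc(C)c(CO)s2)C2CCCCN2)cc1`) differs from compound 2 on an amide-type nitrogen (4-acetylphenyl in place of 4-chloro-3-fluorophenyl on an amide-type nitrogen). For the measured compounds named here, the one measured change at that place is an at least 1.4-fold lower number from compound 1 to compound 2 (0.14 log units; that floor lies within the scatter) and its floor lies within the scatter. The other measured change (a step that the limit leaves unreadable from compound 2 to compound 3) is at a different place and has no readable size. In this assay no step beyond the scatter is therefore expected, and the estimated step is a 1.2-fold higher number from compound 2 to compound 4 (0.06 log units; within the scatter) in this light. Compound 4 is expected at 90000 nM with an estimated range from 35000 nM to 200000 nM as its span.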

Compound 4, half-maximal cytotoxic concentration: > 107000 nM
Compound 4 ended at the assay's limit (the forecaster's own chance of this, stated with the estimate: 45%); middle value at least 1.1-fold (0.07 log units) from the limit.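

In this assay, 4-acetylphenyl in place of 4-chloro-3-fluorophenyl on an amide-type nitrogen gives an at least 1.3-fold higher number from compound 2 to compound 4 (0.13 log units; that floor lies within the scatter), so a phenyl group carrying a carbonyl is now covered at this place, with no step shown beyond the scatter. Compound 4 gives > 107000 nM, which is a limit of the assay. The step between compound 1 and compound 4 cannot be read, so 4-acetylphenyl and 2-fluoro-4-methylphenyl stand unordered.

As far as these compounds go, the true values of compound 1 and compound 4 remain open. Also open, from the compounds shown here alone, is how a 4-carboxyphenyl or 4-aminophenyl group on that nitrogen would read.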